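This account rests on a few compounds, and the source may have more. Where it says the series, first, only, none or still open, it means among the compounds named here.

Compound 1 `COc1cc(-c2nnc3n2NC(c2cccs2)C(C(=O)c2ccc(F)cc2)S3)cc(OC)c1OC` was tested in a functional assay on PC-3 cells (Homo sapiens) for cytotoxicity, read by MTT assay, with a stated time of 48 h (a higher number here means a weaker inhibitor, a lower number a stronger inhibitor), and gave 27400 nM. Compound 2 `COc1cc(-c2nnc3n2NC(c2ccco2)C(C(=O)C2CC2)S3)cc(OC)c1OC` carries a cyclopropyl ketone and a furan in place of the aromatic ketone and thiophene of compound 1. In this assay compound 2 gave 95200 nM. Of the two numbers, compound 2 stands at the higher one, and its gap to compound 1 lies beyond the usual scatter of this kind of measurement; since the two compounds differ in more than one place, nothing more can be read from that pair than the two values themselves.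

Compound 3 `COc1cc(-c2nnc3n2NC(c2ccco2)C(C(=O)c2ccc(Br)cc2)S3)cc(OC)c1OC` has not yet been measured. It differs from compound 2 in a single place (4-bromophenyl in place of cyclopropyl on a carbonyl carbon). The change brings back an aromatic ketone of the kind seen in compound 1, whose number in this assay is the lower of the two. On that basis a modest move toward a lower number is expected, of a size a 2.7-fold lower number from compound 2 to compound 3 (0.43 log units; beyond the scatter) that may only just clear the scatter. For compound 3 the estimate in this assay is 35000 nM, with a likely range from 12000 nM to 100000 nM.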

Compound 3, half-maximal inhibitory concentration: 36400 nM
For compound 3 the middle estimate is 1.0-fold (0.02 log units) below the measured one; the measured number falls inside the stated range.
By their numbers in this assay, from the lowest: compounds 1 and 3 (each within the scatter of the next); then compound 2.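

In this assay the change at the carbonyl carbon can now be read on its own: with the furan and the rest of the core unchanged, putting 4-bromophenyl in place of cyclopropyl gives a 2.6-fold lower number from compound 2 to compound 3 (0.42 log units; beyond the scatter) and counts as a modest step. The earlier pair could not show this, as its two compounds differed in more than one place and the ketone group could not be separated from the change of ring. The result therefore shows that this position responds to the choice of group, but nothing measured here accounts for the step, and it cannot be told whether the six-membered aromatic ring, the bromine or both are responsible.

The compounds shown do not separate the ring from the bromine, and an unsubstituted phenyl or a phenyl carrying a methoxy group on the same carbonyl carbon would address that. Also open, on these data alone, are how a longer alkyl chain, an amine or a carboxylic acid would fare at this place, and whether the same step holds with a thiophene in place of the furan.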